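The source may report more compounds than this note shows. Statements on the series, on what has been measured and on what is new or still open speak of the compounds shown alone.

Measured so far:
- compound 1, `CCCCCCCC/C=C\CCCCCCCC[Se]CCC(=O)NCc1ccc(O)c(OC)c1`: 3200 nM
- compound 2, `CCCCCCCC/C=C\CCCCCCCCCCCC(=O)NCc1ccc(O)c(OC)c1`: 1500 nM

Both compounds share a vanillyl amide head joined to a long unsaturated chain; in compound 1 a selenium atom sits in that chain, while compound 2 carries an all-carbon chain. In an assay on HEK293 cells for antagonist activity at transient receptor potential cation channel subfamily V member 2 (Rattus norvegicus), read by fluorescence and calcium flux, with a stated time of 5 min (a higher number here means a weaker inhibitor, a lower number a stronger inhibitor), compound 1 gives 3200 nM, the highest of the two numbers, and compound 2 gives 1500 nM, a lower number, and the gap between the two lies beyond the scatter of repeated measurements. Within the data shown here, no step between compounds differing in one place has been worked out, so only these two values are known.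

Compound 3, `CCCCCCCC/C=C\CCCCCCCC[Se]C[C@H](N)C(=O)NCc1ccc(O)c(OC)c1`, has not yet been measured. It differs from compound 1 in one place: amino in place of hydrogen on a saturated chain carbon bound to a carbonyl carbon and a saturated chain carbon. Among the measured compounds shown here, nothing among the measured compounds shows what an amino at such a place does, so any expectation rests on the values of compound 1 alone. The step of a 1.3-fold higher number from compound 1 to compound 3 (0.10 log units; within the scatter) is expected to be small, possibly not beyond the scatter, leaning toward a higher number. For compound 3 the estimate in this assay is 4000 nM, within a range of 1500 nM to 12000 nM.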

Compound 3, half-maximal inhibitory concentration: 980 nM
The estimate for compound 3 lay 4.1-fold (0.61 log units) above the measured number, outside the stated range (below it).
By their numbers in this assay, from the lowest: compounds 3 and 2 (each within the scatter of the next); then compound 1.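

In this assay, the change of an amino in place of hydrogen on a saturated chain carbon bound to a carbonyl carbon and a saturated chain carbon gives a 3.3-fold lower number from compound 1 to compound 3 (0.51 log units; beyond the scatter), so the amino goes with a stronger inhibitor here. Among these compounds, the earlier compounds carried nothing but hydrogen at this carbon, so this step is the first sign that the position responds to a change at all, though it rests on one pair of compounds in one assay. Nothing at hand explains why the number falls when the amino is present.

The compounds shown leave open whether the amino itself matters or whether other groups on the same carbon, such as a hydroxyl, a methyl or a carboxylic acid, would give a similar step. They also leave open whether the mirror-image form at that carbon would behave like compound 3, and whether an amino would give a similar step on the all-carbon chain of compound 2.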